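Dipropylamino in Place of a Branched Amine on the Core

This account rests on a few compounds, and the source may have more. Where it says the series, first, only, none or still open, it means among the compounds named here.

In an assay on cell membranes for displacement of a labelled ligand from corticotropin-releasing factor receptor 1 (Rattus norvegicus) (a lower number here means a stronger inhibitor, a higher number a weaker inhibitor), compound 1 `CCCCN(CCC)c1nc(C)nc2c(-c3c(C)cc(N(C)C)nc3C)c(C)nn12` gives 12.8 nM, compound 2 `CCC(CC)Nc1nc(C)nc2c(-c3c(C)cc(N(C)C)nc3C)c(C)nn12` gives 25.6 nM, and compound 3 `CCCCN(CC)c1nc(C)nc2c(-c3ccc(OC)nc3C)c(C)nn12` gives 4.9 nM. Compound 2 thus holds the highest number of the three, though the step of a 2.0-fold higher number from compound 1 to compound 2 (0.30 log units; within the scatter) lies within the scatter, while the gap to compound 3 is beyond it. Compound 4 `CCCN(CCC)c1nc(C)nc2c(-c3c(C)cc(N(C)C)nc3C)c(C)nn12` differs from compound 2 by dipropylamino in place of (pentan-3-yl)amino on an aromatic carbon. Among the measured compounds shown here, the only measured step bearing on this change is the one from compound 1 to compound 2, which was within the scatter, and compound 4 is closely akin to compound 1. The step of a 2.0-fold lower number from compound 2 to compound 4 (0.29 log units; within the scatter) is therefore expected to be small, toward a lower number. Compound 4 is estimated at 13 nM, with a range from 5 nM to 35 nM in this assay.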

Compound 4, half-maximal inhibitory concentration: 14.9 nM
Estimate against measurement, compound 4: 1.1-fold (0.06 log units) below, within the range that was stated.
By their numbers in this assay, from the lowest: compound 3; then compounds 1, 4 and 2 (each within the scatter of the next).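

In this assay, the step of a 1.7-fold lower number from compound 2 to compound 4 (0.24 log units; within the scatter) lies within the scatter, so exchanging (pentan-3-yl)amino, with its hydrogen-bond donor, for dipropylamino, with none, gives no readable difference at this position. Shortening one chain of the amine also gives none, as the step of a 1.2-fold higher number from compound 1 to compound 4 (0.07 log units; within the scatter) is within the scatter too. No measurement here accounts for these results. The compounds shown leave open whether an amine carrying a methoxyethyl chain or a ring such as morpholine at this position would remain within the scatter of these values. They also leave open whether the same exchanges hold with the methoxy-bearing ring of compound 3.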